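Carboxymethyl in place of carboxy on compound 2

The compounds below may be only part of what the source reports. "The series", "measured", "known", "first", "only" and "open" are said of these compounds alone.

In a functional assay on A-375 cells (Homo sapiens) for cytotoxicity, read by CCK-8 assay, with a stated time of 16 h (a higher number here means a weaker inhibitor, a lower number a stronger inhibitor), compound 1 (`COc1ccc(C2=[N+]3C(=Nc4c(-c5ccccc5)c5c(n4[B-]3(F)F)-c3ccc(OCC(=O)O)cc3CC5)C(c3ccccc3)=C2I)cc1`) gives > 50000 nM, which is a limit. Compound 2 (`COc1ccc(C2=[N+]3C(=Nc4c(-c5ccccc5)c5c(n4[B-]3(F)F)-c3ccc(OCC(=O)N[C@@H](CC(=O)O)C(=O)O)cc3CC5)C(c3ccccc3)=C2I)cc1`) gives > 250000 nM, also a limit, so it stands on no number. Compound 3 (`COc1ccc(C2=[N+]3C(=Nc4c(-c5ccccc5)c5c(n4[B-]3(F)F)-c3ccc(OCC(=O)N[C@@H](CCC(=O)O)C(=O)O)cc3CC5)C(c3ccccc3)=C2I)cc1`) carries carboxymethyl in place of carboxy on a saturated chain carbon, two bonds along the chain from an amide-type nitrogen and a carbonyl carbon. Going by the values given here, the only measured step, a step that the two limits leave unreadable from compound 1 to compound 2, has no readable size and offers no size to carry over. The expected step is a number no higher from compound 2 to compound 3 (the limit leaves the size open), with no direction expected beyond the scatter. For compound 3 the estimate is 250000 nM, with an expected range of 100000 nM to 500000 nM.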

Compound 3, half-maximal inhibitory concentration in the A-375 assay: > 250000 nM
Compound 3: no number, only a limit; the forecaster's own chance of this, stated with the estimate: 85%; the middle value lies on the limit itself.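

In the A-375 assay compound 3 gives > 250000 nM and this is a limit. Going by these compounds alone, compound 1 and compound 2 also stand on limits, so no step among the three can be read. How carboxymethyl in place of carboxy alters the response in the A-375 assay is left open by the compounds shown. In a physicochemical assay for lipophilicity (a lower number here means a more polar compound, a higher number a more lipophilic compound), compound 2 gives -0.77 and compound 3 gives -0.74 which makes a number 0.03 log units higher from compound 2 to compound 3 (within the scatter) for this change.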